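Enlarging the Hydroxyl Group: Hydroxymethyl to Hydroxyoxetanyl

This account rests on a few compounds, and the source may have more. Where it says the series, first, only, none or still open, it means among the compounds named here.

Of the compounds shown here, two sharing one core have been tested in an assay on isolated protein for inhibition of ubiquitin carboxyl-terminal hydrolase 7 (Homo sapiens), read by fluorescence, with stated times of 30 min and 1 h; on this read-out higher numbers stand for weaker inhibition and lower numbers for stronger inhibition. Compound 1, `O=C([C@H]1Cc2cc(Cl)cc(-c3ccnc4ccsc34)c2O1)N1CCNCC1`, carries hydrogen on the aromatic carbon in question and gives 90 nM. Compound 2, `O=C([C@H]1Cc2cc(Cl)cc(-c3ccnc4cc(CO)sc34)c2O1)N1CCNCC1`, carries hydroxymethyl there and gives 43 nM. Replacing hydrogen with hydroxymethyl brought a 2.1-fold lower number from compound 1 to compound 2 (0.32 log units; beyond the scatter). Compound 2 therefore stands lowest of the two numbers, with compound 1 above it by more than the scatter.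

Compound 3, `O=C([C@H]1Cc2cc(Cl)cc(-c3ccnc4cc(C5(O)COC5)sc34)c2O1)N1CCNCC1`, continues along this line: 3-hydroxyoxetan-3-yl in place of hydroxymethyl on an aromatic carbon. Among the compounds with values here, the only measured step that bears on this is the one from compound 1 to compound 2, a modest gain on adding a hydroxyl-bearing group. Within the data shown here, the new group keeps a hydroxyl but is larger and ring-shaped, and no measured pair shows what such an enlargement does here. The expected step is thus a 1.1-fold lower number from compound 2 to compound 3 (0.03 log units; within the scatter), within the scatter. Compound 3 is estimated at 40 nM, in a range from 15 nM to 110 nM.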

Compound 3, half-maximal inhibitory concentration: 73 nM
Estimate against measurement, compound 3: 1.8-fold (0.26 log units) below; measured number inside the range.
By their numbers in this assay, from the lowest: compounds 2, 3 and 1 (each within the scatter of the next, the first and the last beyond it).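

Taking 3-hydroxyoxetan-3-yl in place of hydroxymethyl gives a 1.7-fold higher number from compound 2 to compound 3 (0.23 log units; within the scatter) in this assay and so, at this carbon next to the ring sulfur, a group of 5 heavy atoms with a four-membered ring gives a number that cannot be told apart from that of the smaller group. Set against hydrogen, the same group gives a 1.2-fold lower number from compound 1 to compound 3 (0.09 log units; within the scatter) and so, unlike hydroxymethyl, it shows no difference from compound 1 beyond the scatter, which means that carrying a hydroxyl is not enough on its own to secure the modest gain seen with compound 2. Nothing available explains the results for these groups at this position.

As far as these compounds go, a plain methyl, an aminomethyl or a carboxylic acid at this carbon would test whether the hydroxyl matters at all, and that question stays open.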